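From 4-methoxyphenyl to 2-chlorophenyl on the shared core

The compounds below may be only part of what the source reports. "The series", "measured", "known", "first", "only" and "open" are said of these compounds alone.

Among the compounds with values here, in a physicochemical assay for solubility, read by HPLC, in phosphate buffer, measured as kinetic solubility, at pH 7.4 (a lower number here means a less soluble compound, a higher number a more soluble compound), compound 2 `CCC(=O)c1cc(-c2ccc(OC)cc2)n(-c2ccc(S(N)(=O)=O)cc2)c1C` gives 12800 nM, the lower of the two numbers so far, while compound 1 `CCC(=O)c1cc(-c2ccc(F)cc2)n(-c2ccc(S(N)(=O)=O)cc2)c1C` gives 29300 nM. Compound 3 `CCC(=O)c1cc(-c2ccccc2Cl)n(-c2ccc(S(N)(=O)=O)cc2)c1C` carries 2-chlorophenyl in place of 4-methoxyphenyl on an aromatic carbon, next to the ring nitrogen: 2-chlorophenyl in place of 4-methoxyphenyl on an aromatic carbon. Within the data shown here, one measured step bears on this: a 2.3-fold lower number from compound 1 to compound 2 (0.36 log units; beyond the scatter), modest but beyond the scatter. That step also involved methoxy, and compound 3 has none, though a single pair is thin support. The expected change is a modest rise, a 1.4-fold higher number from compound 2 to compound 3 (0.15 log units; within the scatter). For compound 3 the estimate is 18000 nM, with an expected range of 7000 nM to 42000 nM.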

Compound 3, solubility: 38200 nM
Compound 3: the middle estimate sits 2.1-fold (0.33 log units) below what was measured, and the stated range covers the measured number.
By their numbers in this assay, from the lowest: compound 2; then compounds 1 and 3 (each within the scatter of the next).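

In this assay, 2-chlorophenyl in place of 4-methoxyphenyl at this position gives a 3.0-fold higher number from compound 2 to compound 3 (0.47 log units; beyond the scatter) and so leaves compound 2 apart from both halogen-bearing compounds. In place of 4-fluorophenyl, the same group gives a 1.3-fold higher number from compound 1 to compound 3 (0.12 log units; within the scatter) and so does not separate compound 1 from compound 3, even though the halogen and its place on the ring both differ. Nothing available explains these steps.

As far as these compounds go, whether the methoxy group or its place on the ring sets compound 2 apart remains open, as 2-methoxyphenyl and 4-chlorophenyl would separate the two. From the compounds shown here alone, how an amine or a carboxylic acid on this ring would compare also remains open.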